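Removing the carbamate from a pyrrolidine-bearing hydroxamate

The source may report more compounds than this note shows. Statements on the series, on what has been measured and on what is new or still open speak of the compounds shown alone.

Three compounds of a shared core carrying a hydroxamic acid were examined in an assay on isolated protein for inhibition of histone deacetylase 8 (Homo sapiens), read by fluorescence, with a stated time of 30 min; a higher number here means a weaker inhibitor, a lower number a stronger inhibitor. Compound 1 `O=C(COc1ccc2c(c1)CN(C(=O)CCc1ccccc1)[C@H](C(=O)Nc1ccccc1)C2)NO` gives 759 nM. Compound 2 `COc1ccc(NC(=O)[C@@H]2Cc3ccc(OCC(=O)NO)cc3CN2C(=O)[C@@H]2CCCN2C(=O)OC(C)(C)C)cc1` gives 212 nM. Compound 3 `COc1ccc(NC(=O)[C@@H]2Cc3ccc(OCC(=O)NO)cc3CN2C(=O)[C@H](CC(C)C)NC(=O)OC(C)(C)C)cc1` gives 163 nM. Compound 2 thus stands second highest of the three numbers: its gap to compound 3 lies within the scatter, while compound 1 sits at a higher number, beyond the scatter.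

Compound 4 `COc1ccc(NC(=O)[C@@H]2Cc3ccc(OCC(=O)NO)cc3CN2C(=O)[C@@H]2CCCN2)cc1` has not been measured in this assay . It differs from compound 2 in one place: hydrogen in place of tert-butoxycarbonyl on an amine nitrogen in a ring. For the measured compounds named here, no pair of measured compounds shows this kind of change, so no measured step guides the expectation. Because compound 2 gives 212 nM and the change is confined to a single group on a nitrogen, the step from compound 2 to compound 4 is expected to be small, a 1.4-fold higher number from compound 2 to compound 4 (0.15 log units; within the scatter), in no firm direction and likely not beyond the scatter. Compound 4 is therefore estimated at 300 nM, within a range from 80 nM to 1200 nM.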

Compound 4, half-maximal inhibitory concentration: 481 nM
Compound 4: the middle estimate sits 1.6-fold (0.21 log units) below what was measured; the range from low to high includes it.
By their numbers in this assay, from the lowest: compounds 3 and 2 (each within the scatter of the next); then compounds 4 and 1 (each within the scatter of the next).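

In this assay, for the compounds shown here, replacing tert-butoxycarbonyl with hydrogen on the amine nitrogen of the five-membered ring gives a 2.3-fold higher number from compound 2 to compound 4 (0.36 log units; beyond the scatter), a modest step but one beyond the scatter, and the first measured change at this position. The step shows that this group contributes measurably to inhibition in this series, yet it is not required, since compound 4 still gives 481 nM. Nothing available explains the size or direction of this step.

The compounds shown leave open whether a smaller group on this nitrogen, such as acetyl or methyl, would keep the number of compound 2 or stay with that of compound 4. They also leave open whether the same removal from the carbamate nitrogen of compound 3, which lies outside a ring, would give a step of similar size.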